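Benzyl-substituted adenosine nucleosides: antiproliferative screening notes

The compounds below may be only part of what the source reports. "The series", "measured", "known", "first", "only" and "open" are said of these compounds alone.

Measured compounds:
- compound 1 `COc1ccccc1CNc1ncnc2c1ncn2[C@@H]1O[C@H](CO)[C@@H](O)[C@H]1O`: > 166000 nM
- compound 2 `OC[C@H]1O[C@@H](n2cnc3c(NCc4c(F)ccc(F)c4F)ncnc32)[C@H](O)[C@@H]1O`: "not determined" (no result reported)
- compound 3 `OC[C@H]1O[C@@H](n2cnc3c(NCc4ccccc4OC(F)F)ncnc32)[C@H](O)[C@@H]1O`: > 166000 nM

In a functional assay on HOS cells (Homo sapiens) for antiproliferative activity, with a stated time of 72 h (on this read-out higher numbers stand for weaker inhibition and lower numbers for stronger inhibition), compound 1 gives > 166000 nM, which is a limit of the assay and not a number. In this assay compound 3 likewise gives > 166000 nM, again a limit and not a number. In this assay compound 2 gives "not determined" (no result reported), so no result was reported for it. The one step that can be formed, a step that the two limits leave unreadable from compound 1 to compound 3, is therefore unreadable, and the limit of > 166000 nM in this assay, at which 2 of the 3 values shown sit, is the whole of what the shown numbers say.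

Compound 4 `OC[C@H]1O[C@@H](n2cnc3c(NCc4ccc(C(F)(F)F)cc4)ncnc32)[C@H](O)[C@@H]1O` differs from compound 3 as follows: 4-(trifluoromethyl)phenyl in place of 2-(difluoromethoxy)phenyl on a saturated chain carbon bound to a nitrogen on an aromatic ring. Among the compounds with values here, no measured step bears directly on this change, since the only step between measured compounds is unreadable. With both measured values sitting at the limit, there is no ground to expect a readable step in this assay in either direction. Compound 4 is accordingly expected to give about 120000 nM, within 20000 nM to 300000 nM, and the step of an at least 1.3-fold lower number from compound 3 to compound 4 (0.14 log units; that floor lies within the scatter) is estimated with the chance that compound 4 again returns only a limit.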

Compound 4, half-maximal inhibitory concentration: > 166000 nM
Compound 4 ended at the assay's limit (the forecaster's own chance of this, stated with the estimate: 60%); middle value at least 1.3-fold (0.14 log units) away from the limit.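

Compound 4 also returns only a limit in this assay, so the steps from compound 1 and from compound 3 to compound 4 cannot be read: the limit of > 166000 nM in this assay, at which 3 of the 4 values shown sit.

The compounds shown leave open whether any substituent on the shared core gives a measurable number in this assay.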